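Working notes: substituent on the amine nitrogen

The source may report more compounds than this note shows. Statements on the series, on what has been measured and on what is new or still open speak of the compounds shown alone.

Compound 1 `CCOC(=O)C1=C(N/C=N/c2nnc(S(N)(=O)=O)s2)Nc2[nH]nc(C)c2C1c1ccc(N(C)C)cc1` is the reference point here. In a functional assay on HeLa cells (Homo sapiens) for inhibition, read by MTT assay, with a stated time of 48 h (a lower number here means a stronger inhibitor, a higher number a weaker inhibitor), compound 1 gives 26300 nM; of the three numbers recorded so far this is the second highest, nearest to compound 2 `CCOC(=O)C1=C(N/C=N/c2ccc([N+](=O)[O-])cc2)Nc2[nH]nc(C)c2C1c1ccc(N(C)C)cc1`, which gives 57800 nM, and furthest from compound 3 `CCOC(=O)C1=C(N)Nc2[nH]nc(C)c2C1c1ccc(N(C)C)cc1`, which gives 6220 nM.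

Compound 4 `CCOC(=O)C(=NNC1=C(C(=O)OCC)C(c2ccc(N(C)C)cc2)c2c(C)n[nH]c2N1)C(=O)OCC` differs from compound 1 in one place: a group of 12 heavy atoms (7 carbon, 1 nitrogen, 4 oxygen; no ring) in place of a group of 11 heavy atoms (3 carbon, 4 nitrogen, 2 oxygen, 2 sulfur; one five-membered aromatic ring with 3 hetero atoms), on an amine nitrogen. Among the compounds with values here, no measured step covers exactly this change, but the two steps that remove a group from the same amine nitrogen bear on it: a 4.2-fold lower number from compound 1 to compound 3 (0.63 log units; beyond the scatter) and a 9.3-fold lower number from compound 2 to compound 3 (0.97 log units; beyond the scatter). Both show that the shared core with a bare amine nitrogen gives the lowest number, and that a large group at that nitrogen raises it, while a 2.2-fold higher number from compound 1 to compound 2 (0.34 log units; beyond the scatter) shows that exchanging one such group for another moves the number only modestly. Compound 4 again carries a large group on that nitrogen, so its number is expected to stay in the region of compound 1 and compound 2 rather than approach compound 3. Compound 4 is therefore expected to show a 1.3-fold higher number from compound 1 to compound 4 (0.12 log units; within the scatter). The estimate for compound 4 is 35000 nM, within a range of 12000 nM to 100000 nM.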

Compound 4, half-maximal inhibitory concentration: 83800 nM
Estimate against measurement, compound 4: 2.4-fold (0.38 log units) below; the measured number falls inside the stated range.
By their numbers in this assay, from the lowest: compound 3; then compound 1; then compounds 2 and 4 (each within the scatter of the next).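

In this assay the rise over the bare amine nitrogen does not depend on a ring in the group: the ring-free group gives a 13-fold higher number from compound 3 to compound 4 (1.13 log units; beyond the scatter) and so goes the same way as the two ring-bearing groups. Exchanging one large group for another is not uniform either, since replacing the group with the five-membered aromatic ring by the ring-free group gives a 3.2-fold higher number from compound 1 to compound 4 (0.50 log units; beyond the scatter) while replacing the group with the six-membered aromatic ring by the same ring-free group gives a 1.4-fold higher number from compound 2 to compound 4 (0.16 log units; within the scatter) and separates nothing. No measurement at hand explains these differences.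

As far as these compounds go, whether a methyl or an acetyl group on the amine nitrogen keeps the number close to that of compound 3 remains open. So does whether a carboxylic acid in place of the two ethyl esters of the ring-free group would change the number.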